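The compounds below may be only part of what the source reports. "The series", "measured", "known", "first", "only" and "open" are said of these compounds alone.

- Compound 1 `COC1=C(Br)[C@H](O)[C@@]2(C=C1Br)CC(C(=O)NCCCCCNC(=O)C1=NO[C@]3(C=C(Br)C(=O)[C@@H](Br)[C@@H]3O)C1)=NO2`: 4500 nM
- Compound 2 `COC1=C(Br)[C@H](O)[C@@]2(C=C1Br)CC(C(=O)NCCCCCNC(=O)C1=NO[C@]3(C=C(Br)C(OC)(OC)[C@@H](Br)[C@@H]3O)C1)=NO2`: 7100 nM

Both compounds were tested in a functional assay on A549 cells (Homo sapiens) for cytotoxicity, read by sulforhodamine B assay (a lower number here means a stronger inhibitor of growth, a higher number a weaker inhibitor of growth), and the values of compound 1 and compound 2 lie within the scatter of each other, so compound 1 does not stand apart. Compound 3 `COC1=C(Br)[C@H](O)[C@@]2(C=C1Br)CC(C(=O)NCCCCCNC(=O)C1=NO[C@]3(C=C(Br)C(=O)[C@H](Br)[C@@H]3O)C1)=NO2` has not yet been measured. Relative to compound 1, the two compounds have the same atoms and bonds and differ only in configuration as drawn: 1 of 5 stereo elements differ; a stereocentre at a saturated ring carbon is drawn S in compound 1 and R in compound 3: a stereocentre at a saturated ring carbon is drawn S in compound 1 and R in compound 3. For the measured compounds named here, no measured pair shows what such a change does, so no step beyond the scatter is expected. The estimated change, a 1.2-fold higher number from compound 1 to compound 3 (0.09 log units; within the scatter), is small. The expected value for compound 3 is 5500 nM, with an estimated range of 2500 nM to 12000 nM.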

Compound 3, concentration for 50% growth inhibition: 5400 nM
Compound 3: the middle estimate sits 1.0-fold (0.01 log units) above what was measured, within the range that was stated.
By their numbers in this assay, from the lowest: compounds 1, 3 and 2 (each within the scatter of the next).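

For the compounds shown here, the drawn stereocentre at a saturated ring carbon, S in compound 1 and R in compound 3, gives the first comparison in this assay of compounds that differ in one place: a 1.2-fold higher number from compound 1 to compound 3 (0.08 log units; within the scatter). At this position, the drawn configuration does not separate the two compounds in this read-out. This reading rests on a single pair: the fact that compounds 1 and 3 differ only in the configuration as drawn.

The other stereo elements remain untested by any pair shown. Going by these compounds, whether a longer chain between the two amide groups or an added amine on the shared core would give a step beyond the scatter also stays open.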